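From Fluoro to Chloro in a Small Growth-Inhibition Series

The source may report more compounds than this note shows. Statements on the series, on what has been measured and on what is new or still open speak of the compounds shown alone.

Of the compounds shown here, three sharing one core have been measured in a functional assay on cells (Leukemic tumor cell line, Homo sapiens) for inhibition; on this read-out lower numbers stand for stronger inhibition of growth and higher numbers for weaker inhibition of growth. Compound 1 `Cc1ccnc2nc(-c3cccc(Cl)c3)cc(O)c12` gives 100000 nM there. Compound 2 `Cc1ccc2c(O)cc(-c3cccc(Cl)c3)nc2n1` is reported only as a limit of the assay, > 100000 nM. Compound 3 `Cc1cc(C)c2c(O)cc(-c3cccc(F)c3)nc2n1` gives 2450 nM, the lower of the two actual numbers, and its distance from compound 1 lies well beyond the scatter.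

The next compound to be measured is compound 4 `Cc1cc(C)c2c(O)cc(-c3cccc(Cl)c3)nc2n1`. It departs from compound 3 in a single place: chloro in place of fluoro on an aromatic carbon. This puts chloro in place of fluoro on an aromatic carbon of the six-membered aromatic ring of carbon only, meta to a large group. Among the compounds with values here, no measured pair isolates this exchange, so the nearest anchor is compound 3 at 2450 nM. The expected step of a 1.4-fold higher number from compound 3 to compound 4 (0.15 log units; within the scatter) in this assay is slightly toward weaker inhibition of growth, and it is not expected to go beyond the scatter. The upper end of the range is still left wide: compound 1 also carries chloro and gives 100000 nM. For compound 4 the estimated value is 3500 nM, with an expected range from 900 nM to 20000 nM.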

Compound 4, concentration for total growth inhibition: 81300 nM
For compound 4 the middle estimate is 23-fold (1.37 log units) below the measured one, and the stated range ends below it.
By their numbers in this assay, from the lowest: compound 3; then compounds 4 and 1 (each within the scatter of the next).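

Within the data shown here, the first pair to differ only at this position shows that the aromatic carbon meta to a large group is highly sensitive in this assay: chloro in place of fluoro gives a 33-fold higher number from compound 3 to compound 4 (1.52 log units; beyond the scatter). The methyl step on the chloro compounds, by contrast, stays within the scatter, at a 1.2-fold lower number from compound 1 to compound 4 (0.09 log units; within the scatter), so within this pair the extra methyl on an aromatic carbon leaves the read-out effectively unmoved. The same methyl exchange from compound 2 can be read only as a floor, an at least 1.2-fold lower number from compound 2 to compound 4 (0.08 log units; that floor lies within the scatter), since the value of compound 2 is a limit and not a number: the limit of > 100000 nM in this assay, at which 1 of the 4 values shown sits.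

The compounds shown leave open whether the lower number seen with fluoro belongs to fluoro alone or would also appear with other groups at this carbon, such as hydrogen, methoxy or an amine. Among these compounds, they also leave open whether fluoro would give a similarly low number on the cores of compound 1 and compound 2, as the only fluoro compound carries both methyl groups.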